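Urea-to-benzamide step in a diaryl pyrazole growth-inhibitor series

The source may report more compounds than this note shows. Statements on the series, on what has been measured and on what is new or still open speak of the compounds shown alone.

Measured so far:
compound 1 `COc1cc(-c2nn(-c3cccc(NC(=O)Nc4cc(C(F)(F)F)cc(C(F)(F)F)c4)c3)cc2-c2ccncc2)ccc1Cl` — 1860 nM
compound 2 `COc1cc(-c2nn(-c3cccc(NC(=O)Nc4cccc(C(F)(F)F)c4)c3)cc2-c2ccncc2)ccc1Cl` — 14300 nM

Within the data shown here, compound 2 stands highest of the two numbers in a functional assay on SW-620 cells (Homo sapiens) for inhibition, read by sulforhodamine B assay, with a stated time of 48 h; a lower number here means a stronger inhibitor of growth, a higher number a weaker inhibitor of growth; the only step measured, a 7.7-fold higher number from compound 1 to compound 2 (0.89 log units; beyond the scatter), is the removal of one trifluoromethyl. Compound 3 `COc1cc(-c2nn(-c3cccc(NC(=O)c4ccccc4)c3)cc2-c2ccncc2)ccc1Cl` carries a further cut at the same place: phenyl in place of (3-(trifluoromethyl)phenyl)amino on a carbonyl carbon. Among the measured compounds shown here, the one step that bears on it ran toward weaker growth inhibition, so a further rise of the number is expected, a 2.4-fold higher number from compound 2 to compound 3 (0.39 log units; beyond the scatter). The estimate for compound 3 in this assay is 35000 nM, with a range from 9000 nM to 120000 nM.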

Compound 3, concentration for total growth inhibition: > 100000 nM
Compound 3: a limit, no number; the forecaster's own chance of this, stated with the estimate: 20%; middle value at least 2.8-fold (0.45 log units) from the limit.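

In this assay, phenyl in place of (3-(trifluoromethyl)phenyl)amino on the carbonyl carbon gives an at least 6.9-fold higher number from compound 2 to compound 3 (0.84 log units; beyond the scatter). The reading for compound 3 is a limit of the assay, not a number: the limit of > 100000 nM in this assay, at which 1 of the 3 values shown sits. Both steps at this position now run toward weaker growth inhibition, and the second removes the amino group and the trifluoromethyl together.

The shares of those two losses remain unseparated. Also open, as far as these compounds go, is how a benzamide keeping a trifluoromethyl on its phenyl, or a piperidine on the carbonyl carbon, would read.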